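A few compounds are considered here, and "the series" means these few. Any claim that something is new, unique, unknown or untested is made for them only; others in the source may bear on it.

Measured compounds and their values:

Compound 1 `CCNC(=O)N1CCN(C(=S)SCc2cn(Cc3ccc(F)cc3)nn2)CC1` gives 44400 nM in a functional assay on SMMC-7721 cells (Homo sapiens) for cytotoxicity, read by MTT assay, with a stated time of 72 h; a lower number here means a stronger inhibitor, a higher number a weaker inhibitor.
Compound 2 `CC(C)NC(=O)N1CCN(C(=S)SCc2cn(Cc3ccc(F)cc3)nn2)CC1` gives 5970 nM in this assay.
Compound 3 `CCNC(=O)N1CCN(C(=S)SCc2cn(Cc3ccc(Cl)cc3)nn2)CC1` gives only a limit of the assay, > 128000 nM, in this assay.

Compounds 1 and 2 share the same core and differ in one place: methyl in place of hydrogen on a saturated chain carbon bound to an amide-type nitrogen and a saturated chain carbon. This single change brought a 7.4-fold lower number from compound 1 to compound 2 (0.87 log units; beyond the scatter).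

Compound 3 carries a different core from compound 1; the difference is chloro in place of fluoro on an aromatic carbon. The step is an at least 2.8-fold higher number from compound 1 to compound 3 (0.45 log units; beyond the scatter). Its size is known only as a bound, as the value of compound 3 sits at the limit (the limit of > 128000 nM in this assay, at which 1 of the 3 values shown sits).

Compound 4 `CC(C)NC(=O)N1CCN(C(=S)SCc2cn(Cc3ccc(Cl)cc3)nn2)CC1` has not yet been measured. It differs from compound 3 by methyl in place of hydrogen on a saturated chain carbon bound to an amide-type nitrogen and a saturated chain carbon. Within the data shown here, this is the same change as the one from compound 1 to compound 2, made at a place described in the same words, so the step from compound 1 to compound 2 is the nearest guide to what compound 4 should do. The expected step is an at least 3.6-fold lower number from compound 3 to compound 4 (0.56 log units; beyond the scatter), which rests on the step of a 7.4-fold lower number from compound 1 to compound 2 (0.87 log units; beyond the scatter) applied to the core of compound 3. Compound 3 is known only as a limit (the limit of > 128000 nM in this assay, at which 1 of the 3 values shown sits), so the starting point is itself uncertain and compound 4 could again fall at that limit. Compound 4 is therefore expected to give about 35000 nM in this assay, with a likely range from 12000 nM to 128000 nM.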

Compound 4, half-maximal inhibitory concentration: > 128000 nM
Compound 4 ended at the assay's limit; the forecaster's own chance of this, stated with the estimate: 35%; middle value at least 3.6-fold (0.56 log units) from the limit.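

The change from ethyl to isopropyl brought a 7.4-fold lower number from compound 1 to compound 2 (0.87 log units; beyond the scatter) on the core of compound 1 in this assay, but on the core of compound 3 the step cannot be read, so these compounds neither confirm nor rule out that the change carries over from one core to the other: the limit of > 128000 nM in this assay, at which 2 of the 4 values shown sit.

The other change in this set, chloro in place of fluoro, can be read on the isopropyl compounds, where it brought an at least 21-fold higher number from compound 2 to compound 4 (1.33 log units; beyond the scatter). This shows that chloro goes with a much higher number on both cores, but it does not show whether the size of that step depends on the core: the same change on two cores in this assay, an at least 2.8-fold higher number (0.45 log units; beyond the scatter) from compound 1 to compound 3 and an at least 21-fold higher number (1.33 log units; beyond the scatter) from compound 2 to compound 4; the limit leaves it open whether they differ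

The compounds shown leave open whether isopropyl lowers the number at all when chloro is present, which would need a chloro compound with a value that is not a limit, perhaps one carrying a longer chain such as butyl or a ring such as cyclopropyl in place of ethyl. They also leave open how groups such as bromo or methoxy would compare with fluoro and chloro at that aromatic carbon.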